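Swapping the aryl ring on the core: compound 3 to compound 4

A few compounds are considered here, and "the series" means these few. Any claim that something is new, unique, unknown or untested is made for them only; others in the source may bear on it.

The three measured compounds share one core and differ only in the group attached to an aromatic carbon of it. Compound 1 `O=C1C[C@H](O)C[C@@H](/C=C/c2c(Cl)cc(Cl)cc2CCc2ccccc2)O1` carries a phenethyl group and gives 430 nM in an assay for inhibition of 3-hydroxy-3-methylglutaryl-coenzyme A reductase (Rattus norvegicus); a lower number here means a stronger inhibitor, a higher number a weaker inhibitor. Compound 2 `O=C1C[C@H](O)C[C@@H](/C=C/c2c(Cl)cc(Cl)cc2-c2ccc(Cl)c(Cl)c2)O1` carries a 3,4-dichlorophenyl group and gives 25 nM. Compound 3 `Cc1cccc(-c2cc(Cl)cc(Cl)c2/C=C/[C@@H]2C[C@@H](O)CC(=O)O2)c1` carries a 3-methylphenyl group and gives 16 nM; this number sits within the scatter of compound 2, while compound 1 stands far apart, as the steps of a 17-fold lower number from compound 1 to compound 2 (1.24 log units; beyond the scatter) and a 27-fold lower number from compound 1 to compound 3 (1.43 log units; beyond the scatter) show.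

Compound 4 `O=C1C[C@H](O)C[C@@H](/C=C/c2c(Cl)cc(Cl)cc2-c2cc(Cl)cc(Cl)c2)O1` has not been measured. It differs from compound 3 in one place: 3,5-dichlorophenyl in place of 3-methylphenyl on an aromatic carbon. The step that bears most directly on this change is a 1.6-fold lower number from compound 2 to compound 3 (0.19 log units; within the scatter), which shows that exchanging a dichlorophenyl group for a 3-methylphenyl group moved the number only within the scatter. The two large steps from compound 1 concern the phenethyl group and say nothing about one substituted phenyl against another.

On this basis the author expects compound 4 to stay close to compound 3, with a step of a 1.3-fold higher number from compound 3 to compound 4 (0.10 log units; within the scatter) that remains within the scatter. The estimate for compound 4 is 20 nM, with a range from 8 nM to 50 nM.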

Compound 4, half-maximal inhibitory concentration: 37 nM
Compound 4: middle estimate off by 1.9-fold (0.27 log units), on the low side; the measured number falls inside the stated range.
By their numbers in this assay, from the lowest: compounds 3, 2 and 4 (each within the scatter of the next, the first and the last beyond it); then compound 1.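

In this assay, among the compounds shown here, the step of a 2.3-fold higher number from compound 3 to compound 4 (0.36 log units; beyond the scatter) is the first exchange of one substituted phenyl group for another to pass beyond the scatter, although only modestly, so the pattern of substituents on this ring can shift the number. By contrast, the step of a 1.5-fold higher number from compound 2 to compound 4 (0.17 log units; within the scatter) stays within the scatter, so the 3,4-dichlorophenyl and 3,5-dichlorophenyl groups cannot be told apart at this position, while the step of a 12-fold lower number from compound 1 to compound 4 (1.07 log units; beyond the scatter) shows that a third substituted phenyl group also stands far from the phenethyl compound. No measurement is available that explains these differences.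

The compounds shown leave open whether an unsubstituted phenyl group, a 3-chlorophenyl group or a 3,5-dimethylphenyl group would fall in the same narrow range, and the last of these would help show whether the gap between compound 3 and compound 4 follows the number of substituents or their identity. Going by these compounds, it also remains open how far this position would accept a methoxy group, an amine or a carboxylic acid on the phenyl ring.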